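Lengthening the Chain of Compound 2

This account rests on a few compounds, and the source may have more. Where it says the series, first, only, none or still open, it means among the compounds named here.

Compound 2 `CCCCCCCCCCCCNC(=O)[C@@H](NC(=O)c1cc2ccccc2[nH]1)[C@@H](C)O` is the starting point. In a functional assay on SW-620 cells (Homo sapiens) for cytotoxicity, read by MTT assay, with a stated time of 48 h (on this read-out higher numbers stand for weaker inhibition and lower numbers for stronger inhibition), compound 2 gives 18800 nM, the lowest of the two plain numbers reported. The closest neighbour is compound 1 `CCCCCCCCCCCCNC(=O)[C@@H](NC(=O)c1cccs1)[C@@H](C)O`, which in this assay gives 29200 nM; the step of a 1.6-fold lower number from compound 1 to compound 2 (0.19 log units; within the scatter) stays within the scatter. Compound 3 `CCCCCCCCCCCCNC(=O)[C@@H](NC(=O)c1cc2ccccc2n1C)[C@@H](C)O` carries a methyl on the aromatic nitrogen. In this assay compound 3 reaches only the limit > 200000 nM, which is a boundary of the assay rather than a number (the limit of > 200000 nM in this assay, at which 1 of the 3 values shown sits). From it follow the steps of an at least 10-fold higher number from compound 2 to compound 3 (1.02 log units; beyond the scatter) and an at least 6.8-fold higher number from compound 1 to compound 3 (0.83 log units; beyond the scatter).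

Compound 4 `CCCCCCCCCCCCCCNC(=O)[C@@H](NC(=O)c1cc2ccccc2[nH]1)[C@@H](C)O` keeps everything in compound 2 except the long chain, where the change is ethyl in place of hydrogen on a saturated chain carbon, ten or more bonds along the chain from an amide-type nitrogen. None of the three measured steps touches that chain; each of them concerns the ring attached to the carbonyl carbon, so no direct evidence exists for how a longer chain behaves here. In the absence of such evidence the expectation is a step within the scatter, in no particular direction. Compound 4 is therefore expected to give 18800 nM, somewhere between 6000 nM and 60000 nM. This estimate means an expected step of no change at the digits printed from compound 2 to compound 4 (within the scatter).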

Compound 4, half-maximal inhibitory concentration: 15200 nM
Estimate against measurement, compound 4: 1.2-fold (0.09 log units) above; the measured number falls inside the stated range.
By their numbers in this assay, from the lowest: compounds 4, 2 and 1 (each within the scatter of the next). At a limit, above all of these: compound 3.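

Among these compounds, the steps among the earlier compounds all concerned the ring on the carbonyl carbon, so this is the first view of what happens along the long chain. In this assay, ethyl in place of hydrogen on a saturated chain carbon, ten or more bonds along the chain from an amide-type nitrogen, gives a 1.2-fold lower number from compound 2 to compound 4 (0.09 log units; within the scatter), so adding these 2 carbons leaves the read-out indistinguishable from that of the shorter chain, unlike the methyl on the aromatic nitrogen, which gives an at least 10-fold higher number from compound 2 to compound 3 (1.02 log units; beyond the scatter). No measurement shown here bears on why the longer chain behaves in this way.

As far as these compounds go, whether a shorter chain, a still longer chain, or a chain ending in an amine or a carboxylic acid would stay within the scatter of compound 2 remains open, and a single step in chain length cannot establish a trend. From the compounds shown here alone, how the longer chain behaves with thiophen-2-yl on the carbonyl carbon in place of 1H-indol-2-yl also stays open.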